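Swapping Dimethylamino for Nitro: Expecting a Weaker Inhibitor

This account rests on a few compounds, and the source may have more. Where it says the series, first, only, none or still open, it means among the compounds named here.

Compound 1, `COc1cc(OC)c(OC)cc1/C=C/C(=O)c1ccc(OC)c2c1OC(C)(C)C=C2`, gives a limit of > 10000 nM in a functional assay on SK-OV-3 cells (Homo sapiens) for antiproliferative activity, read by MTT assay, with a stated time of 24 h; a lower number here means a stronger inhibitor, a higher number a weaker inhibitor.
Compound 2, `COc1ccc(C(=O)/C=C/c2ccc(F)cc2)c2c1C=CC(C)(C)O2`, gives a limit of > 10000 nM in this assay.
Compound 3, `COc1ccc(C(=O)/C=C/c2ccc(N(C)C)cc2)c2c1C=CC(C)(C)O2`, gives 2750 nM in this assay.

Among these three, compound 3 is the only one with a real number; the other two sit at the limit of > 10000 nM in this assay, at which 2 of the 3 values shown sit, so they are limits rather than measurements. Among the compounds with values here, the one step that can be sized, an at least 3.6-fold lower number from compound 2 to compound 3 (0.56 log units; beyond the scatter), shows that putting dimethylamino where fluoro had been turned a limit into a measurable number.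

Compound 4, `COc1ccc(C(=O)/C=C/c2ccc([N+](=O)[O-])cc2)c2c1C=CC(C)(C)O2`, differs from compound 3 only in that (nitro in place of dimethylamino on an aromatic carbon). Within the data shown here, no measured pair shows this particular exchange, so the step from compound 2 to compound 3 is the nearest guide: it indicates that the dimethylamino group is tied to the measurable activity of compound 3, and that another group in the same position gave a limit. It is therefore expected that compound 4 will be a weaker inhibitor than compound 3, with a step of about a 2.9-fold higher number from compound 3 to compound 4 (0.46 log units; beyond the scatter) in this assay. The estimate for compound 4 is 8000 nM, with a likely range from 2500 nM to 20000 nM, and a fair chance that only a limit is reported.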

Compound 4, half-maximal inhibitory concentration: 3420 nM
For compound 4 the middle estimate is 2.3-fold (0.37 log units) above the measured one; the measured number falls inside the stated range.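

In this assay, the new result shows that the measurable activity of compound 3 does not depend on dimethylamino in particular, since nitro at the same place, on an aromatic carbon para to a large group, gives a number that cannot be told apart from it: a 1.2-fold higher number from compound 3 to compound 4 (0.09 log units; within the scatter). Both groups also improve on fluoro, with nitro giving an at least 2.9-fold lower number from compound 2 to compound 4 (0.46 log units; beyond the scatter), a step that stands alongside the earlier at least 3.6-fold lower number from compound 2 to compound 3 (0.56 log units; beyond the scatter). So fluoro, not dimethylamino, now looks like the exception among the three groups compared at this place, and compound 2 itself remains only a limit of the assay: the limit of > 10000 nM in this assay, at which 2 of the 4 values shown sit.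

With only three groups compared here, the compounds shown cannot tell whether most groups at this place on the shared core would give a measurable number, or whether dimethylamino and nitro share some feature that fluoro lacks. A primary amine, a carboxylic acid or a longer chain such as butyl at the same place would help to separate these two readings, and the compounds shown give no cause for the result.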